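A few compounds are considered here, and "the series" means these few. Any claim that something is new, unique, unknown or untested is made for them only; others in the source may bear on it.

Going by the values given here, in a toxicity assay on L02 cells (Homo sapiens) for cytotoxicity, read by MTT assay, with a stated time of 72 h (a higher number here means a weaker inhibitor, a lower number a stronger inhibitor), compound 2 `CCCN1CCN(CCCCn2c3c(c4ccccc42)C(=O)c2c[n+]([O-])c4ccccc4c2C3=O)CC1` gives 6830 nM, the higher of the two numbers measured so far, while compound 1 `O=C1c2c[n+]([O-])c3ccccc3c2C(=O)c2c1c1ccccc1n2CCCCN1CCCCC1` gives 610 nM. The next compound, compound 3 `O=C1c2c[n+]([O-])c3ccccc3c2C(=O)c2c1c1ccccc1n2CCN1CCCCC1`, differs from compound 2 as follows: piperidin-1-yl in place of 2-(4-propylpiperazin-1-yl)ethyl on a saturated chain carbon, two bonds along the chain from an aromatic nitrogen. In words, piperidin-1-yl stands in place of 2-(4-propylpiperazin-1-yl)ethyl on a saturated chain carbon, two bonds along the chain from an aromatic nitrogen. Among the compounds with values here, only one measured step bears on this change: an 11-fold higher number from compound 1 to compound 2 (1.05 log units; beyond the scatter), a large rise on swapping piperidin-1-yl for 4-propylpiperazin-1-yl, four bonds along the chain from an aromatic nitrogen. Within the data shown here, compound 3 returns to piperidin-1-yl, but at two bonds rather than four, and no measured step tests that difference. A drop of similar size is therefore expected, an estimated 8.5-fold lower number from compound 2 to compound 3 (0.93 log units; beyond the scatter). For compound 3 the expected value is 800 nM, with an estimated range from 200 nM to 3000 nM.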

Compound 3, half-maximal inhibitory concentration: 1050 nM
Compound 3: the middle estimate sits 1.3-fold (0.12 log units) below what was measured; low and high end bracket the measured number.
By their numbers in this assay, from the lowest: compounds 1 and 3 (each within the scatter of the next); then compound 2.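

In this assay, shortening the chain that carries piperidin-1-yl makes no change beyond the usual scatter (a 1.7-fold higher number from compound 1 to compound 3 (0.24 log units; within the scatter)). The larger step (a 6.5-fold lower number from compound 2 to compound 3 (0.81 log units; beyond the scatter)) alters the chain and the end group together, but since chain length alone shows no effect here, the higher number of compound 2 goes with 4-propylpiperazin-1-yl rather than with the longer chain, at least among these three compounds. Nothing at hand explains why the end group matters in this assay.

The compounds shown leave open whether 4-propylpiperazin-1-yl on the shorter chain would also give a high number, and whether the propyl group or the piperazine ring itself is what counts. A morpholine at the chain end, or a plain piperazine, could help separate those two.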